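From fluoro to trifluoromethoxy in compound 3

A few compounds are considered here, and "the series" means these few. Any claim that something is new, unique, unknown or untested is made for them only; others in the source may bear on it.

In a functional assay on VCaP cells (Homo sapiens) for antiproliferative activity, read by propidium iodide staining, with a stated time of 96 h (on this read-out higher numbers stand for weaker inhibition and lower numbers for stronger inhibition), compound 1 (`CC(O)(CSc1ccc(F)cc1)C(=O)Nc1cccc(S(F)(F)(F)(F)F)c1`) gives 21900 nM, and compound 2 (`CC(O)(CS(=O)(=O)c1ccc(F)cc1)C(=O)Nc1ccc(S(F)(F)(F)(F)F)cc1`) gives 34200 nM. These two values lie within the scatter of each other, so compound 2 stands level with compound 1. Compound 3 (`CC(O)(CS(=O)(=O)c1ccc(OC(F)(F)F)cc1)C(=O)Nc1ccc(S(F)(F)(F)(F)F)cc1`) carries trifluoromethoxy in place of fluoro on an aromatic carbon, para to a large group (trifluoromethoxy in place of fluoro on an aromatic carbon). For the measured compounds named here, no measured pair shows a single change, so the expectation rests on the structural change alone. In this assay the expected step, a 1.7-fold lower number from compound 2 to compound 3 (0.23 log units; within the scatter), stays within the scatter, leaning toward stronger inhibition. Compound 3 is estimated at 20000 nM, with an expected range of 7000 nM to 50000 nM.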

Compound 3, half-maximal inhibitory concentration: 95800 nM
Beside the measured number, compound 3's estimate is 4.8-fold (0.68 log units) below it, and the stated range ends below it.
By their numbers in this assay, from the lowest: compounds 1 and 2 (each within the scatter of the next); then compound 3.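

In this assay, trifluoromethoxy in place of fluoro on an aromatic carbon, para to a large group, gives a 2.8-fold higher number from compound 2 to compound 3 (0.45 log units; beyond the scatter), a modest step toward weaker inhibition and the first single-place change available here. This position is therefore not indifferent to the group it carries, though one pair shows no trend. No available evidence bears on why the step occurs. On these data alone, whether chloro, methoxy or an amine at this carbon would stand nearer compound 2 or compound 3 remains open. Also open, as far as these compounds go, is whether the same exchange would give a similar step on the core of compound 1.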